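The source may hold more compounds than are shown below. What is called first, only, known or untested is meant among the compounds shown, and "the series" means these compounds.

In a functional assay on MT4 cells (Homo sapiens) for cytotoxicity (a lower number here means that less compound is tolerated, a higher number that more compound is tolerated), compound 1 `Cc1ccc(C(=O)CSc2nc(O)c(C)c(Cc3cccc4ccccc34)n2)cc1` gives >= 251000 nM, which is a limit and not an exact number. Compound 2 `Cc1c(O)nc(SCC(=O)c2ccc(F)cc2)nc1Cc1cccc2ccccc12` gives >= 275000 nM, and this too is a limit. Compound 2 therefore has no exact value to serve as a starting point. Compound 3 `Cc1c(O)nc(SCC(=O)c2ccc(Cl)cc2)nc1Cc1cccc2ccccc12` differs from compound 2 in one substituent, with chloro in place of fluoro on an aromatic carbon, para to a large group (chloro in place of fluoro on an aromatic carbon). Within the data shown here, one measured step bears on this change, as it also swaps a single group on an aromatic carbon: a step that the two limits leave unreadable from compound 1 to compound 2, with fluoro in place of methyl. Among the measured compounds shown here, with only that unreadable step to go on, no shift beyond the scatter is expected in this assay. The expected change is an at least 1.3-fold lower number from compound 2 to compound 3 (0.13 log units; that floor lies within the scatter). For compound 3 the estimate is 200000 nM, with an expected range of 60000 nM to 300000 nM.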

Compound 3, half-maximal cytotoxic concentration: >= 198000 nM
Compound 3 gave a limit, no number; the forecaster's own chance of this, stated with the estimate: 65%; the middle value is on the limit's open side.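

In this assay, among these compounds, compound 3 gives >= 198000 nM, which is a limit, and compound 1 and compound 2 also have only limits, so no step among the three can be read. On these data alone, whether methyl, fluoro or chloro on the aromatic carbon changes tolerance stays open.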